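From acetyl to methyl on a shared core

The source may hold more compounds than are shown below. What is called first, only, known or untested is meant among the compounds shown, and "the series" means these compounds.

Measured in a functional assay on SK-BR-3 cells (Homo sapiens) for cytotoxicity, read by sulforhodamine B assay, with a stated time of 3 days; a higher number here means that more compound is needed for the effect, a lower number that less compound is needed:
- compound 1 `CCOCc1c(C)coc1-c1ccc2c(c1OC)CCCC2(C)C`: 19.8 uM
- compound 2 `COc1c(-c2occ(C)c2COC(C)=O)ccc2c1CCCC2(C)C`: 14 uM

For the measured compounds named here, compound 2, at 14 uM, stands within the scatter of compound 1, the only other measured compound. Compound 3 `COCc1c(C)coc1-c1ccc2c(c1OC)CCCC2(C)C` has methyl in place of acetyl on an oxygen on a saturated carbon. Going by the values given here, the one measured step bearing on this place, with acetyl in place of ethyl, is a 1.4-fold lower number from compound 1 to compound 2 (0.15 log units; within the scatter). That step gives no ground to expect a change beyond the scatter in this assay. The expected step is a 1.3-fold higher number from compound 2 to compound 3 (0.11 log units; within the scatter). Compound 3 is estimated at 18 uM, with an expected range of 9 uM to 35 uM.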

Compound 3, concentration for half-maximal effect: 18.5 uM
Compound 3: middle estimate off by 1.0-fold (0.01 log units), on the low side; the range from low to high includes it.
By their numbers in this assay, from the lowest: compounds 2, 3 and 1 (each within the scatter of the next).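

In this assay, methyl in place of acetyl on this oxygen gives a 1.3-fold higher number from compound 2 to compound 3 (0.12 log units; within the scatter), and hydrogen in place of methyl on the saturated chain carbon bound to that oxygen gives a 1.1-fold lower number from compound 1 to compound 3 (0.03 log units; within the scatter). Across acetyl, ethyl and methyl, then, no step at this position lies beyond the scatter, whether or not the group carries a carbonyl. Nothing available explains this insensitivity.

The compounds shown leave open whether a free hydroxyl, an amine or a longer chain such as octyl at this place would give a step beyond the scatter.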